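The source may hold more compounds than are shown below. What is called first, only, known or untested is meant among the compounds shown, and "the series" means these compounds.

The measured compounds:
compound 1, `O=C(/C(=C\c1ccccc1OCc1ccccc1)SCc1ccc(F)cc1)c1ccc(Cl)cc1`, gives 1000 nM in a functional assay on DU-145 cells (Homo sapiens) for inhibition, read by trypan blue exclusion, with a stated time of 96 h; on this read-out lower numbers stand for stronger inhibition of growth and higher numbers for weaker inhibition of growth
compound 2, `COc1ccccc1/C=C(/SCc1ccc(F)cc1)C(=O)c1ccc(Cl)cc1`, gives 10000 nM
compound 3, `Cc1ccc(/C=C(/SCc2ccc(F)cc2)C(=O)c2ccc(Cl)cc2)s1`, gives only a limit of this assay, not a number: > 100000 nM

Compound 2 holds the highest of the two numbers, set apart from compound 1 by a 10-fold higher number from compound 1 to compound 2 (1.00 log units; beyond the scatter). Compound 3 sits at a limit, (the limit of > 100000 nM in this assay, at which 1 of the 3 values shown sits). Compound 4, `COc1ccccc1/C=C(/Sc1ccc(Br)cc1)C(=O)c1ccc(Cl)cc1`, differs from compound 2 in one place: 4-bromophenyl in place of 4-fluorobenzyl on a sulfur. Neither measured step touches the group on the sulfur: a 10-fold higher number from compound 1 to compound 2 (1.00 log units; beyond the scatter) and an at least 10-fold higher number from compound 2 to compound 3 (1.00 log units; beyond the scatter) both alter the aromatic ring on the double-bonded chain carbon, so they give no direct guide. The step of no change at the digits printed from compound 2 to compound 4 (within the scatter) is therefore expected to stay within the scatter, in no set direction. Compound 4 is expected to give 10000 nM, with a range from 2000 nM to 50000 nM in this assay.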

Compound 4, concentration for 50% growth inhibition: 10000 nM
For compound 4 middle estimate and measured number coincide at the digits printed; the measured number falls inside the stated range.
By their numbers in this assay, from the lowest: compound 1; then compounds 2 and 4 (each within the scatter of the next). At a limit, above all of these: compound 3.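

In this assay, among these compounds, 4-bromophenyl in place of 4-fluorobenzyl on the sulfur gives no change at the digits printed from compound 2 to compound 4 (within the scatter), the first measured step at this position. On the core of compound 2, this swap of one aromatic group for another leaves growth inhibition unmoved, although it changes both the halogen and the way the ring is linked to the sulfur. Nothing measured here accounts for this result. On these data alone, it remains open whether either of those two changes alone would also leave the number in place, or whether the same swap would do so on the core of compound 1. A carboxylic acid or a longer chain on the sulfur could also behave quite differently.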